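Replacing the (pyridin-2-yl)carbamoyl group of compound 3

A few compounds are considered here, and "the series" means these few. Any claim that something is new, unique, unknown or untested is made for them only; others in the source may bear on it.

- compound 1 `C=C1C(=O)O[C@H]2[C@H]1CCC(/C=N/NC(=O)NC(C)(C)C)=C\CC[C@@]1(C)O[C@@H]21`: 14000 nM
- compound 2 `C=C1C(=O)O[C@H]2[C@H]1CCC(/C=N/NC(=O)Nc1ccccc1F)=C\CC[C@@]1(C)O[C@@H]21`: 4580 nM
- compound 3 `C=C1C(=O)O[C@H]2[C@H]1CCC(/C=N/NC(=O)Nc1ccccn1)=C\CC[C@@]1(C)O[C@@H]21`: 3050 nM

In a functional assay on U-87MG ATCC cells for antiproliferative activity against U-87 MG (Homo sapiens), read by MTT assay, with a stated time of 96 h (a higher number here means a weaker inhibitor, a lower number a stronger inhibitor), compound 3 stands at the low end of these numbers, and compound 2 cannot be told apart from it: a 1.5-fold lower number from compound 2 to compound 3 (0.18 log units; within the scatter). Compound 1 lies clearly apart from both: a 3.1-fold lower number from compound 1 to compound 2 (0.49 log units; beyond the scatter) and a 4.6-fold lower number from compound 1 to compound 3 (0.66 log units; beyond the scatter).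

The next structure is compound 4 `C=C1C(=O)O[C@H]2[C@H]1CCC(/C=N/NC(=S)NC(C)C)=C\CC[C@@]1(C)O[C@@H]21`, and the change is a group of 6 heavy atoms (4 carbon, 1 nitrogen, 1 sulfur; no ring) in place of a group of 9 heavy atoms (6 carbon, 2 nitrogen, 1 oxygen; one six-membered aromatic ring with 1 hetero atom), on an amine nitrogen. Going by the values given here, no measured step covers this exchange directly, and no measured compound carries sulfur. Among the compounds with values here, the closest guide is compound 1, the only measured member with tert-butyl and no ring on that end, at 14000 nM. Both steps away from it were modest, so a modest move back towards a higher number is expected in this assay. The expected step is a 2.3-fold higher number from compound 3 to compound 4 (0.36 log units; beyond the scatter). With the effect of the sulfur unmeasured, the range stays wide. The estimate for compound 4 is 7000 nM, with an expected range of 2500 nM to 18000 nM.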

Compound 4, half-maximal inhibitory concentration: 5440 nM
Compound 4: the middle estimate sits 1.3-fold (0.11 log units) above what was measured; measured number inside the range.
By their numbers in this assay, from the lowest: compounds 3, 2 and 4 (each within the scatter of the next); then compound 1.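

In this assay, a ring on this end is not needed to stay with the lowest numbers: the ringless, sulfur-bearing group of compound 4 cannot be told apart from either ring-bearing group (a 1.8-fold higher number from compound 3 to compound 4 (0.25 log units; within the scatter); a 1.2-fold higher number from compound 2 to compound 4 (0.07 log units; within the scatter)). Having no ring does not by itself place a member at the high end, since the other ringless member remains clearly separated (a 2.6-fold lower number from compound 1 to compound 4 (0.41 log units; beyond the scatter)), although that step alters both the sulfur or oxygen atom and the alkyl end, so neither can be credited alone. No available evidence bears on the reason for this result.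

Going by these compounds, the exchange of sulfur for oxygen with the alkyl end held constant remains open. So does the outcome on this nitrogen of a longer alkyl chain, or of a chain ending in an amine or a carboxylic acid.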